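Cyclohexyl removal on the ring nitrogen of the benzimidazole series

The source may hold more compounds than are shown below. What is called first, only, known or untested is meant among the compounds shown, and "the series" means these compounds.

Measured so far:
compound 1 `Fc1ccc(-c2nc3cc(C(F)(F)F)ccc3[nH]2)cc1` gives 25000 nM in an ADME assay on BHK cells (Mesocricetus auratus) for cytotoxicity, read by MTT assay, with a stated time of 96 h; a lower number here means that less compound is tolerated, a higher number that more compound is tolerated
compound 2 `O=[N+]([O-])c1ccc(-c2nc3cc(C(F)(F)F)ccc3n2C2CCCCC2)cc1` gives > 100000 nM in this assay

Compound 2 stands at the upper limit of this assay: its value is not a number but a limit, (the limit of > 100000 nM in this assay, at which 1 of the 2 values shown sits). Compound 1, which carries hydrogen on the ring nitrogen and a fluorophenyl group, gives a number in this assay, 25000 nM.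

Compound 3 `O=[N+]([O-])c1ccc(-c2nc3cc(C(F)(F)F)ccc3[nH]2)cc1` differs from compound 2 by hydrogen in place of cyclohexyl on an aromatic nitrogen. Among the measured compounds shown here, no measured pair shows this change, so its size can only be guessed. Compound 1 gives 25000 nM and is the other compound bearing hydrogen on the ring nitrogen. On that ground compound 3 is expected to return a measurable number, a step of an at least 2.2-fold lower number from compound 2 to compound 3 (0.34 log units; beyond the scatter) that may just exceed the scatter. Compound 3 is therefore estimated at 45000 nM in this assay, within 15000 nM to 130000 nM.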

Compound 3, half-maximal cytotoxic concentration: 18000 nM
Compound 3: the middle estimate sits 2.5-fold (0.40 log units) above what was measured, within the range that was stated.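

In this assay the ring nitrogen now shows a step of its own: hydrogen in place of cyclohexyl at this position gives an at least 5.5-fold lower number from compound 2 to compound 3 (0.74 log units; beyond the scatter) and moves the series from a limit to a number. At the other place, nitro in place of fluoro on an aromatic carbon gives a 1.4-fold lower number from compound 1 to compound 3 (0.14 log units; within the scatter) and leaves compound 1 and compound 3 indistinguishable in this read-out. Compound 2 remains a limit, so the step from it has only one bound: the limit of > 100000 nM in this assay, at which 1 of the 3 values shown sits.

Still open, going by these compounds, is where a methyl group, or a longer chain ending in an amine, on the ring nitrogen would fall relative to hydrogen and cyclohexyl. Also open, on these data alone, is whether cyclohexyl on the ring nitrogen gives a comparable step when fluoro replaces nitro on the aromatic carbon.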